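This account rests on a few compounds, and the source may have more. Where it says the series, first, only, none or still open, it means among the compounds named here.

Compound 3, `Nc1ccccc1NC(=O)c1ccc(Cn2cnc3c(Nc4cccc(OC(F)(F)F)c4)nc(Cl)nc32)cc1`, is the lowest of the three measured compounds in a functional assay on NCI-H460 cells (Homo sapiens) for antiproliferative activity, read by CCK-8 assay, with a stated time of 72 h, tested at 8 uM (a lower number here means a weaker effect, a higher number a stronger effect of the compound at the concentration tested), where compound 3 gives 62.4%. Its nearest neighbour is compound 2, `Nc1ccccc1NC(=O)/C=C/c1ccc(Cn2cnc3c(Nc4cccc(OC(F)(F)F)c4)nc(Cl)nc32)cc1`, for which 66.7% is recorded, and the change a number 4.3 percentage points lower from compound 2 to compound 3 (within the scatter) stays within the scatter. Compound 1, `Nc1ccccc1NC(=O)c1ccc(Cn2cnc3c(Nc4ccccc4)nc(Cl)nc32)cc1`, gives 77.8% and stands furthest away, the step of a number 15.4 percentage points lower from compound 1 to compound 3 (beyond the scatter) being beyond the scatter.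

The next compound, compound 4, `CN1CCN(c2nc(Cl)nc3c2ncn3Cc2ccc(C(=O)Nc3ccccc3N)cc2)CC1`, differs from compound 3 in one place: 4-methylpiperazin-1-yl in place of (3-(trifluoromethoxy)phenyl)amino on an aromatic carbon. For the measured compounds named here, none of the measured steps tests this change directly. The step from compound 1 to compound 3 concerns only a trifluoromethoxy group on the leaving aromatic ring, and the step from compound 2 to compound 3 concerns the linker, which compound 4 keeps. Going by the values given here, the replacement of the whole (3-(trifluoromethoxy)phenyl)amino group by 4-methylpiperazin-1-yl therefore has no measured precedent here, and a step in either direction, or none beyond the scatter, is possible.

Compound 4 is expected to come in near 58%, somewhere between 35% and 78%. This estimate implies a step of a number 4.4 percentage points lower from compound 3 to compound 4 (within the scatter), which is expected to remain inside the scatter.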

Compound 4, a percentage reported as inhibition, at one concentration (the size of the read-out at that concentration, not a potency): 55.1%
Compound 4: middle estimate off by 2.9 percentage points, on the high side, within the range that was stated.
By their numbers in this assay, from the lowest: compounds 4, 3 and 2 (each within the scatter of the next, the first and the last beyond it); then compound 1.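

In this assay, for the compounds shown here, the position on the aromatic carbon next to the ring nitrogen accepts a non-aromatic ring in place of the whole (3-(trifluoromethoxy)phenyl)amino group, as the exchange gives a number 7.3 percentage points lower from compound 3 to compound 4 (within the scatter), so the earlier aromatic substituents are not the only groups here compatible with a read-out of this order at the concentration tested. The comparison with the plain anilino group adds a second reading, a number 22.7 percentage points lower from compound 1 to compound 4 (beyond the scatter), which shows that compound 4 does not match compound 1, although it remains within the scatter of compound 3. No measurement given here accounts for either step, and the reason for them remains unknown.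

What the compounds shown leave open is how a morpholin-4-yl ring, an open-chain dimethylamino group or an unsubstituted piperazin-1-yl ring would read at this same aromatic carbon. They also leave open whether 4-methylpiperazin-1-yl would give a similar reading alongside the 2-((2-aminophenyl)carbamoyl)ethenyl group of compound 2, and how these single-concentration readings would translate into potency.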